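A few compounds are considered here, and "the series" means these few. Any claim that something is new, unique, unknown or untested is made for them only; others in the source may bear on it.

Compound 1 `Cc1cc2c(C(=O)NCC#N)cccc2n1-c1nc2c(c(NCc3ccccc3)n1)CCCC2` gives 468 nM in a functional assay on MIA PaCa-2 cells (Homo sapiens) for antiproliferative activity; a lower number here means that less compound is needed, a higher number that more compound is needed for the effect. Compound 2 `CC#CCNC(=O)c1cccc2c1cc(C)n2-c1nc2c(c(NCc3ccccc3)n1)CCCC2` gives 723 nM. Compound 3 `CC#CC(=O)Nc1cccc2c1cc(C)n2-c1nc2c(c(NCc3ccccc3)n1)CCCC2` gives 436 nM.

Among these three numbers compound 1 stands second highest; compound 3 is nearest, with a 1.1-fold lower number from compound 1 to compound 3 (0.03 log units; within the scatter), and compound 2 furthest, with a 1.5-fold higher number from compound 1 to compound 2 (0.19 log units; within the scatter). Compound 4 `C=CC#CC(=O)Nc1cccc2c1cc(C)n2-c1nc2c(c(NCc3ccccc3)n1)CCCC2` differs from compound 1 in that (a group of 7 heavy atoms (5 carbon, 1 nitrogen, 1 oxygen; no ring) in place of a group of 6 heavy atoms (3 carbon, 2 nitrogen, 1 oxygen; no ring), on an aromatic carbon). The change most like this one is the step from compound 1 to compound 3, which also replaced the (cyanomethyl)carbamoyl group on an aromatic carbon and stayed within the scatter; the step from compound 2 to compound 3 was within the scatter as well. Compound 4 is therefore expected to land close to compound 1, with a 1.1-fold lower number from compound 1 to compound 4 (0.05 log units; within the scatter) not going beyond the scatter. The estimate for compound 4 is 420 nM, between 200 nM and 900 nM.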

Compound 4, half-maximal effective concentration in the MIA PaCa-2 assay: 892 nM
Compound 4: middle estimate off by 2.1-fold (0.33 log units), on the low side; low and high end bracket the measured number.
By their numbers in the MIA PaCa-2 assay, from the lowest: compounds 3, 1, 2 and 4 (each within the scatter of the next, the first and the last beyond it).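

In the MIA PaCa-2 assay, where compound 4 gives 892 nM, vinyl in place of methyl on a triple-bonded carbon gives the only step among these compounds beyond the scatter, a modest one: a 2.0-fold higher number from compound 3 to compound 4 (0.31 log units; beyond the scatter); the other two stay within it: a 1.9-fold higher number from compound 1 to compound 4 (0.28 log units; within the scatter) and a 1.2-fold higher number from compound 2 to compound 4 (0.09 log units; within the scatter). In a physicochemical assay for pharmacokinetics, read by LC-MS, in phosphate buffer, tested at 1 uM (a higher number here means that the compound lasts longer, a lower number that the compound disappears faster), replacing (cyanomethyl)carbamoyl on the aromatic carbon also gives a step beyond the scatter: an at least 4.7-fold lower number from compound 1 to compound 4 (0.67 log units; beyond the scatter). In the physicochemical assay compound 4 gives 5.08 h. In the physicochemical assay compound 1 gives > 24 h, which stands at a limit of the assay, not at a number: the limit of > 24 h in the physicochemical assay, at which 1 of the 2 values shown sits.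

The compounds shown leave open whether an amine or a longer chain in place of vinyl on the triple-bonded carbon would shift the number in the MIA PaCa-2 assay, and how such a group would behave in the physicochemical assay.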